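The compounds below may be only part of what the source reports. "The series", "measured", "known", "first", "only" and "open" are said of these compounds alone.

Measured so far:
compound 1 `COc1ccc(-c2csc(N/N=C/c3ccc(Cl)cc3Cl)n2)cc1` — 78.1%
compound 2 `Clc1ccc(-c2csc(N/N=C/c3ccc(Cl)cc3Cl)n2)cc1` — 76%

Among the measured compounds shown here, in a functional assay, read by spectrophotometry, with a stated time of 15 min, tested at 20 ug/mL (a higher number here means a stronger effect of the compound at the concentration tested, a lower number a weaker effect), compound 2 gives 76% and compound 1 gives 78.1%; the one step between them, a number 2.1 percentage points lower from compound 1 to compound 2 (within the scatter), is within the scatter, so the two numbers cannot be told apart. Compound 3 `Clc1ccc(/C=N/Nc2nc(-c3ccccc3)cs2)c(Cl)c1` has not yet been measured. It differs from compound 2 by hydrogen in place of chloro on an aromatic carbon. For the measured compounds named here, the only measured step, chloro in place of methoxy on an aromatic carbon, concerns a different exchange at this same ring and is within the scatter; no measured step removes the chloro altogether. The bearing of the known step on this change is therefore weak, and no step beyond the scatter in this assay is expected in either direction. Compound 3 is estimated to give 72%, with a range from 55% to 85%. This estimate means an expected step of a number 4 percentage points lower from compound 2 to compound 3 (within the scatter) in this assay.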

Compound 3, a percentage reported as inhibition, at one concentration (the size of the read-out at that concentration, not a potency): 78.1%
Beside the measured number, compound 3's estimate is 6.1 percentage points below it; the range from low to high includes it.
By their numbers in this assay, from the lowest: compounds 2, 1 and 3 (each within the scatter of the next).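

In this assay, taking the substituent away altogether at this position, on an aromatic carbon para to a large group, leaves no readable step: 4-chlorophenyl to phenyl gives a number 2.1 percentage points higher from compound 2 to compound 3 (within the scatter), and hydrogen in place of methoxy gives no change at the digits printed from compound 1 to compound 3 (within the scatter). The earlier pair compared only one substituent with another, whereas hydrogen, chloro and methoxy can now all be set side by side here and cannot be told apart. No measured evidence bears on a cause for this.

Going by these compounds, whether an amine, a carboxylic acid or a longer chain at this position would give a step beyond the scatter remains open. On these data alone, these are read-outs at one concentration, so whether the three compounds would differ in effect at any other concentration also remains open.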